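Moving the chlorine on the benzyl group of compound 2

This account rests on a few compounds, and the source may have more. Where it says the series, first, only, none or still open, it means among the compounds named here.

Compound 1, `N#Cc1c(Nc2ccccc2Cl)nc(SCc2cn(Cc3ccccc3Cl)nn2)nc1-c1ccccc1`: compound 1 gives 28500 nM in a functional assay on ECa-109 cells (Homo sapiens) for inhibition, read by MTT assay, with a stated time of 72 h; a lower number here means a stronger inhibitor, a higher number a weaker inhibitor.
Compound 2, `Cc1ccccc1Nc1nc(SCc2cn(Cc3ccccc3Cl)nn2)nc(-c2ccccc2)c1C#N`: compound 2 gives 9740 nM in this assay.
Compound 3, `N#Cc1c(Nc2ccccc2)nc(SCc2cn(Cc3ccccc3Cl)nn2)nc1-c1ccccc1`: compound 3 gives > 64000 nM in this assay, which is a limit of the assay and not a number.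

Compound 2 stands lowest of the two numbers given; the nearest is compound 1, as a 2.9-fold lower number from compound 1 to compound 2 (0.47 log units; beyond the scatter) shows, a step beyond the scatter. Compound 4, `Cc1ccccc1Nc1nc(SCc2cn(Cc3ccc(Cl)cc3)nn2)nc(-c2ccccc2)c1C#N`, differs from compound 2 only in one place: 4-chlorophenyl in place of 2-chlorophenyl on a saturated chain carbon bound to an aromatic nitrogen. The three measured steps all change the group on the anilino ring, not the benzyl group on the triazole: a 2.9-fold lower number from compound 1 to compound 2 (0.47 log units; beyond the scatter), an at least 2.2-fold higher number from compound 1 to compound 3 (0.35 log units; beyond the scatter) and an at least 6.5-fold higher number from compound 2 to compound 3 (0.81 log units; beyond the scatter). None of them bears on the position altered in compound 4, so the measured data give no direction for this change. Compound 4 is therefore expected to show no step beyond the scatter in this assay, that is no change at the digits printed from compound 2 to compound 4 (within the scatter). The estimate for compound 4 in this assay is 9740 nM, with a range from 3000 nM to 32000 nM.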

Compound 4, half-maximal inhibitory concentration: > 64000 nM
Compound 4 was reported as a limit; the forecaster's own chance of this, stated with the estimate: 10%; at least 6.5-fold (0.81 log units) between middle value and limit.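

Of the steps shown, this is the only one at the benzyl group, and it shows that this place is not indifferent in this assay: replacing 2-chlorobenzyl with 4-chlorobenzyl gives an at least 6.5-fold higher number from compound 2 to compound 4 (0.81 log units; beyond the scatter) on an otherwise unchanged structure. The two groups have the same atoms, so this step goes with where the chlorine sits on the benzyl ring and not with which atoms are present. The result for compound 4 is a limit and not a number, the same limit that compound 3 reaches: the limit of > 64000 nM in this assay, at which 2 of the 4 values shown sit.

The compounds shown leave open whether an unsubstituted benzyl group, a fluorobenzyl group or a longer chain such as phenethyl at this place would keep the activity of compound 2. They also leave open whether 4-chlorobenzyl would act in the same way on compound 1.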